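Methoxy to hydroxy on compound 1

The source may hold more compounds than are shown below. What is called first, only, known or untested is meant among the compounds shown, and "the series" means these compounds.

Values so far in a functional assay on A549 cells (Homo sapiens) for cytotoxicity, read by MTT assay, with a stated time of 72 h; on this read-out lower numbers stand for stronger inhibition and higher numbers for weaker inhibition
- compound 1 `COc1cc(/C=C/C(=O)Nc2cc3c(Nc4ccc(F)c(Cl)c4)ncnc3cc2O[C@H]2CCOC2)cc(OC)c1OC` gives 4150 nM
- compound 2 `COc1ccc(/C=C/C(=O)Nc2cc3c(Nc4ccc(F)c(Cl)c4)ncnc3cc2OC)cc1` gives "not active" (no number reported)
- compound 3 `COc1cc2ncnc(Nc3ccc(F)c(Cl)c3)c2cc1NC(=O)/C=C/c1cc(OC)c(OC)c(OC)c1` gives "not active" (no number reported)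

Compound 1 is the only one of the three with a number, so it has no numerical neighbour to be ranked against. Compound 2 and compound 3 were reported without a number.

The next compound is compound 4 `COc1cc(/C=C/C(=O)Nc2cc3c(Nc4ccc(F)c(Cl)c4)ncnc3cc2O[C@H]2CCOC2)cc(OC)c1O`. Its difference from compound 1 is hydrogen in place of methyl on an oxygen on an aromatic ring. In words, this is hydrogen in place of methyl on an oxygen on an aromatic ring, methoxy to hydroxy, so that 3,4,5-trimethoxyphenyl becomes 4-hydroxy-3,5-dimethoxyphenyl.

Within the data shown here, no measured pair differs in one place only, so nothing measured gives the size or direction of this change. In this assay the working expectation is therefore no step beyond the usual scatter, with no favoured direction and with wide uncertainty on both sides. The estimated step is a 1.0-fold lower number from compound 1 to compound 4 (0.02 log units; within the scatter). The anchor for this is compound 1 at 4150 nM. A report without a number also remains possible, as seen for compound 2 at "not active" (no number reported). For compound 4 the expected value is 4000 nM, within an estimated range of 1500 nM to 12000 nM.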

Compound 4, half-maximal inhibitory concentration: 27000 nM
Estimate against measurement, compound 4: 6.8-fold (0.83 log units) below, and the stated range ends below it.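

In this assay, among these compounds, the first single-place step is a 6.5-fold higher number from compound 1 to compound 4 (0.81 log units; beyond the scatter), so this oxygen on the aromatic ring is not a silent site: the methyl there cannot be exchanged for hydrogen without a change beyond the scatter. The direction is towards weaker inhibition, with 3,4,5-trimethoxyphenyl ahead of 4-hydroxy-3,5-dimethoxyphenyl in this pair, although this rests on one modest step and sets no pattern for the series. Nothing available gives a cause for this step.

As far as these compounds go, it remains open whether the loss follows from removing the methyl alone or from having hydrogen on this oxygen, and an ethyl or a longer chain ending in an amine on the same oxygen would separate those readings. From the compounds shown here alone, it is also open whether methoxy to hydroxy at the other methoxy groups of the 3,4,5-trimethoxyphenyl ring gives a step of similar size, and compound 2 and compound 3, which have no reported number, offer no further comparison.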